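This account rests on a few compounds, and the source may have more. Where it says the series, first, only, none or still open, it means among the compounds named here.

Compound 1 `O=S(=O)(NCCCNCC1COc2ccccc2O1)c1cc(C(F)(F)F)cc(C(F)(F)F)c1` was measured in a functional assay on MIA PaCa-2 cells (Homo sapiens) for inhibition, read by MTT assay, with a stated time of 72 h (on this read-out lower numbers stand for stronger inhibition of growth and higher numbers for weaker inhibition of growth), where compound 1 gives 2600 nM. Compound 2 `O=S(=O)(NCCCNCc1cccc(Cl)c1)c1cc(C(F)(F)F)cc(C(F)(F)F)c1` is the 3-chlorophenyl analogue, and in this assay compound 2 gives 4400 nM. Among the measured compounds shown here, the step of a 1.7-fold higher number from compound 1 to compound 2 (0.23 log units; within the scatter) is the only measured comparison at this position, and it stays within the scatter, so compound 2 stands alongside compound 1 with the two numbers not distinguishable from each other. Compound 3 `COc1ccccc1CNCCCNS(=O)(=O)c1cc(C(F)(F)F)cc(C(F)(F)F)c1` carries the change (2-methoxyphenyl in place of 3-chlorophenyl on a saturated chain carbon bound to an amine nitrogen). For the measured compounds named here, the one measured step that bears on it, a 1.7-fold higher number from compound 1 to compound 2 (0.23 log units; within the scatter), shows that swapping the group on this chain carbon moved the number little; on that basis no step beyond the scatter is expected in this assay for compound 3, in either direction. Compound 3 is therefore estimated at 3500 nM, with a range from 1500 nM to 8000 nM, which corresponds to an expected step of a 1.3-fold lower number from compound 2 to compound 3 (0.10 log units; within the scatter).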

Compound 3, concentration for 50% growth inhibition: 3100 nM
Estimate against measurement, compound 3: 1.1-fold (0.05 log units) above; low and high end bracket the measured number.
By their numbers in this assay, from the lowest: compounds 1, 3 and 2 (each within the scatter of the next).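

In this assay, a 1.4-fold lower number from compound 2 to compound 3 (0.15 log units; within the scatter) shows that replacing 3-chlorophenyl with 2-methoxyphenyl, which exchanges a chlorine-bearing ring for one with a hydrogen-bond acceptor, does not separate the two compounds. Likewise, a 1.2-fold higher number from compound 1 to compound 3 (0.08 log units; within the scatter) does not separate 2-methoxyphenyl from 2,3-dihydro-1,4-benzodioxin-2-yl. This position on a saturated chain carbon bound to an amine nitrogen has now taken three different groups, and all three steps among them lie within the scatter. No supporting measurement accounts for this similarity. From the compounds shown here alone, it remains open whether a carboxylic acid on the aromatic ring, a pyridine ring in place of the benzene ring, or an added amine at this position would give a step beyond the scatter. A longer chain joining the two nitrogens is equally untested by the compounds shown.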